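This account rests on a few compounds, and the source may have more. Where it says the series, first, only, none or still open, it means among the compounds named here.

Compound 1 `CSc1nc(=O)ccn1[C@@H]1O[C@H](COP(=O)(O)OP(=O)(O)O)[C@@H](O)[C@H]1O` is the reference point of this set. For the measured compounds named here, in an in vitro functional assay on 1321-N1 cells for agonist activity at P2Y purinoceptor 6 (Homo sapiens), read by scintillation proximity assay and inositol phosphate accumulation (on this read-out higher numbers stand for an effect only at larger amounts of compound and lower numbers for an effect already at smaller amounts), compound 1 gives 4700 nM, the only outright number among the two values shown. Compound 2 `CSc1nc(=O)ccn1[C@@H]1O[C@H](COP(=O)(O)O)[C@@H](O)[C@H]1O` differs from compound 1 by a hydrogen atom in place of a group of 4 heavy atoms (3 oxygen, 1 phosphorus; no ring), on an oxygen. In this assay compound 2 reaches only a limit of the assay, not a number, at > 100000 nM (the limit of > 100000 nM in this assay, at which 1 of the 2 values shown sits). That change produces an at least 21-fold higher number from compound 1 to compound 2 (1.32 log units; beyond the scatter). Compound 3 `O=c1ccn([C@@H]2O[C@H](COP(=O)(O)OP(=O)(O)O)[C@@H](O)[C@H]2O)c(SCCc2ccccc2)n1` is a different variation of compound 1, carrying (benzyl in place of hydrogen on a saturated chain carbon bound to a sulfur). Going by the values given here, no measured step touches that place; the one measured step concerns the oxygen-bound group, so it offers no direct guide for the sulfur-bound carbon. A step of modest size at most, in either direction, is therefore expected, a 1.6-fold lower number from compound 1 to compound 3 (0.19 log units; within the scatter). Compound 3 is estimated at 3000 nM, with a range from 600 nM to 15000 nM.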

Compound 3, half-maximal effective concentration: 2500 nM
The estimate for compound 3 lay 1.2-fold (0.08 log units) above the measured number; the range from low to high includes it.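

Swapping methylsulfanyl for phenethylsulfanyl gives a 1.9-fold lower number from compound 1 to compound 3 (0.27 log units; within the scatter) in this assay. The sulfur-bound chain can therefore carry benzyl, with its six-membered aromatic ring, and the two numbers still fall within the usual scatter of each other, unlike the large step seen earlier at the oxygen. The data shown give no reason for this outcome.

This is a single pair, so it cannot show how far the position stretches: an amine, a carboxylic acid or a longer chain in place of benzyl might behave quite differently. Also open, on these data alone, is whether the phenethylsulfanyl group would give a similar result on the shorter oxygen-bound group of compound 2.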